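From pyrazolylamino to benzamido on the shared core

The compounds below may be only part of what the source reports. "The series", "measured", "known", "first", "only" and "open" are said of these compounds alone.

In a physicochemical assay for solubility, read by LC-MS, in phosphate buffer, with a stated time of 24 h, at pH 7.4 (a higher number here means a more soluble compound, a lower number a less soluble compound), compound 3 `CN(c1ccn(C)n1)c1cnc(NCc2c(F)ccc3c2CCO3)n2cnnc12` gives 130000 nM and so holds the lower of the two actual numbers. In this assay compound 2 `COCCC(=O)Nc1cnc(NCc2c(F)ccc3c2CCO3)n2cnnc12` stands higher at 980000 nM and the gap between them is modest (a 7.5-fold lower number from compound 2 to compound 3 (0.88 log units; beyond the scatter)). Compound 1 `O=C(Nc1ccccc1)c1cnc(NCc2c(F)ccc3c2CCO3)n2cnnc12` gives < 1000 nM in this assay and this is a limit of the assay, not a number.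

Going to compound 4 `O=C(Nc1cnc(NCc2c(F)ccc3c2CCO3)n2cnnc12)c1ccccc1` puts benzamido in place of methyl(1-methyl-1H-pyrazol-3-yl)amino on an aromatic carbon and the rest of the structure stays the same. Two measured changes bear on this: an at least 130-fold higher number from compound 1 to compound 3 (2.11 log units; beyond the scatter) and an at least 980-fold higher number from compound 1 to compound 2 (2.99 log units; beyond the scatter) are both large, and both rest on that limit. Benzamido carries the same six-membered aromatic ring of carbon only as the phenylcarbamoyl of compound 1, with the amide turned round, while its amide nitrogen sits on the core as in compound 2. Compound 4 is therefore expected to lie much nearer compound 1 than compound 3. The estimated change is large and downward, namely a 22-fold lower number from compound 3 to compound 4 (1.34 log units; beyond the scatter) in this assay by this reckoning. For compound 4 the estimate is 6000 nM with an expected range from 1000 nM to 40000 nM as the likely span.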

Compound 4, solubility: 2000 nM
Compound 4: the middle estimate sits 3.0-fold (0.48 log units) above what was measured; the range from low to high includes it.
By their numbers in this assay, from the lowest: compound 4; then compound 3; then compound 2. At a limit, below all of these: compound 1.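

In this assay, within the data shown here, the new result gives the first reading of a six-membered aromatic ring of carbon only joined to this aromatic carbon through an amide nitrogen, and the step is a 65-fold lower number from compound 3 to compound 4 (1.81 log units; beyond the scatter). The earlier compounds shown here could not separate the amide from what it carries, but the pair that keeps the amide on the core and changes only the group on the carbonyl carbon now does so, with phenyl in place of 2-methoxyethyl: a 490-fold lower number from compound 2 to compound 4 (2.69 log units; beyond the scatter), so an amide nitrogen at this position does not by itself go with a high number. The remaining step, an at least 2.0-fold higher number from compound 1 to compound 4 (0.30 log units; that floor lies within the scatter), rests on a limit of the assay and not a number, so the two orientations of the amide cannot be placed in order beyond that floor: the limit of < 1000 nM in this assay, at which 1 of the 4 values shown sits.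

The compounds shown leave open whether the large step belongs to the phenyl ring itself or to the loss of the ether chain, which a pyridine ring or a plain ethyl chain on the same carbonyl carbon would help to separate. They also leave open how a morpholine or a carboxylic acid carried on the phenyl ring of compound 4 would read in this assay.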